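Amide-end heteroaryl exchange: compound 3 to compound 4

This account rests on a few compounds, and the source may have more. Where it says the series, first, only, none or still open, it means among the compounds named here.

Measured in an in vitro functional assay on CHO/Galpha16 cells for antagonist activity at C-C chemokine receptor type 8 (Homo sapiens), read by FLIPR; a lower number here means a stronger inhibitor, a higher number a weaker inhibitor:
Compound 1 `CCCC(=O)N1CCC(NS(=O)(=O)c2ccc(NC(=O)c3cccc(C)c3)c3ccccc23)CC1` gives 5.1 nM.
Compound 2 `CCCC(=O)N1CCC(NS(=O)(=O)c2ccc(NC(=O)c3ccc(C)cc3)c3ccccc23)CC1` gives 9.5 nM.
Compound 3 `CCCC(=O)N1CCC(NS(=O)(=O)c2ccc(NC(=O)c3ccoc3)c3ccccc23)CC1` gives 1520 nM.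

Compound 3 holds the highest number of the three: a 160-fold higher number from compound 2 to compound 3 (2.20 log units; beyond the scatter) and a 300-fold higher number from compound 1 to compound 3 (2.47 log units; beyond the scatter), both large, whereas a 1.9-fold higher number from compound 1 to compound 2 (0.27 log units; within the scatter). Compound 4 `CCCC(=O)N1CCC(NS(=O)(=O)c2ccc(NC(=O)c3nccn3C)c3ccccc23)CC1` differs from compound 3 by 1-methyl-1H-imidazol-2-yl in place of furan-3-yl on a carbonyl carbon. Going by the values given here, no measured step exchanges one five-membered aromatic ring for another; the two large steps show only that furan-3-yl falls far behind either methylphenyl and give no direction for a second heteroaryl in its place. Compound 4 is therefore expected to sit close to compound 3 in this assay, with wide uncertainty. The expected step is a 1.3-fold lower number from compound 3 to compound 4 (0.10 log units; within the scatter). The estimate for compound 4 is 1200 nM, range 300 nM to 5000 nM.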

Compound 4, half-maximal inhibitory concentration: 20.4 nM
Compound 4: middle estimate off by 59-fold (1.77 log units), on the high side, outside the stated range (below it).
By their numbers in this assay, from the lowest: compounds 1 and 2 (each within the scatter of the next); then compound 4; then compound 3.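

Replacing furan-3-yl with 1-methyl-1H-imidazol-2-yl on this carbonyl carbon gives a 75-fold lower number from compound 3 to compound 4 (1.87 log units; beyond the scatter) and so a five-membered aromatic ring here does not by itself carry the loss seen with furan-3-yl. The methylphenyl amides still hold an edge, with a 2.1-fold higher number from compound 2 to compound 4 (0.33 log units; beyond the scatter) and a 4.0-fold higher number from compound 1 to compound 4 (0.60 log units; beyond the scatter) so the gap to them depends on which five-membered ring is present. Nothing measured here explains the gain. The compounds shown leave open whether the methyl group or the second ring nitrogen matters more. An unmethylated imidazol-2-yl or a thiazol-2-yl amide would help separate the two.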